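The source may hold more compounds than are shown below. What is called first, only, known or untested is meant among the compounds shown, and "the series" means these compounds.

Measured compounds:

Compound 1, `Cc1cccc(N2CC(C)NC(=O)N2)n1`, in a functional assay on cells for inhibition of Polyunsaturated fatty acid 5-lipoxygenase (Homo sapiens); on this read-out higher numbers stand for weaker inhibition and lower numbers for stronger inhibition: 1700 nM
Compound 2, `CC1CN(c2cccc(Cl)n2)NC(=O)N1`, in this assay: 1600 nM
Compound 3, `CC1CN(c2cccc(Cl)c2)NC(=O)N1O`, in this assay: 3600 nM

Compound 2 and compound 1 differ in one place, (methyl in place of chloro on an aromatic carbon). This change gave a 1.1-fold higher number from compound 2 to compound 1 (0.03 log units; within the scatter), so the two numbers cannot be told apart. Compound 3 stands apart from both: its number is the highest of the three, and its gaps to compound 1 and compound 2 lie beyond the scatter. How the core of compound 3 differs from the core of compound 2 is not broken down here.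

Compound 4, `Cc1cccc(N2CC(C)N(O)C(=O)N2)c1`, is not yet measured. It differs from compound 3 by methyl in place of chloro on an aromatic carbon. Among the compounds with values here, this is the same kind of change as the one from compound 2 to compound 1, though not the same: there the change sat on a six-membered aromatic ring with one nitrogen, next to the ring nitrogen and meta to a group of 8 heavy atoms, whereas here it sits on a six-membered aromatic ring of carbon only, meta to a group of 9 heavy atoms. Since the earlier step was a 1.1-fold higher number from compound 2 to compound 1 (0.03 log units; within the scatter), compound 4 is expected to show a step of a 1.0-fold lower number from compound 3 to compound 4 (0.01 log units; within the scatter), staying within the scatter of compound 3. Compound 4 is therefore estimated at 3500 nM, most likely between 1500 nM and 8000 nM.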

Compound 4, half-maximal inhibitory concentration: 4800 nM
Estimate against measurement, compound 4: 1.4-fold (0.14 log units) below, within the range that was stated.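

In this assay, methyl in place of chloro on an aromatic carbon gave a 1.3-fold higher number from compound 3 to compound 4 (0.12 log units; within the scatter), so on the core of compound 3 the two numbers cannot be told apart. Set beside the earlier case, the change behaved alike on both cores: the same change on two cores in this assay, a 1.1-fold higher number (0.03 log units; within the scatter) from compound 2 to compound 1 and a 1.3-fold higher number (0.12 log units; within the scatter) from compound 3 to compound 4, 1.3-fold (0.10 log units) apart, within the scatter of two such steps. Within the data shown here, this shows that, across these two cores, the swap produced no step that can be told from the scatter, but it does not show that methyl and chloro can be exchanged freely on other cores or at other places, and two steps give no effect size worth carrying forward.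

The compounds shown leave open whether a group other than methyl or chloro on that aromatic carbon, such as methoxy, an amine or a carboxylic acid, would move the number beyond the scatter. Among these compounds, they also include no pair that differs in the core alone, so the part the core itself plays in the gaps around compound 3 remains unresolved.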